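Swapping acetamido for dimethylcarbamoyl on the shared core

The source may report more compounds than this note shows. Statements on the series, on what has been measured and on what is new or still open speak of the compounds shown alone.

In a toxicity assay on CCRF-CEM cells (Homo sapiens) for cytotoxicity (a lower number here means that less compound is tolerated, a higher number that more compound is tolerated), compound 2 `CC(=O)Nc1cccc2c1nc(-c1c(F)cccc1F)n2Cc1c(F)cccc1F` gives 39.3 uM. Compound 1 `CCc1cccc2c1nc(-c1c(F)cccc1F)n2Cc1c(F)cccc1F`, which has ethyl in place of acetamido on the same aromatic carbon of the shared core, gives 26.1 uM. The measured change is a 1.5-fold higher number from compound 1 to compound 2 (0.18 log units; within the scatter), so these two values cannot be told apart. Compound 3 `CC(=O)N(C)c1cccc2c1nc(-c1c(F)cccc1F)n2Cc1c(F)cccc1F` reaches only a limit of the assay, > 100 uM.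

The next compound is compound 4 `CN(C)C(=O)c1cccc2c1nc(-c1c(F)cccc1F)n2Cc1c(F)cccc1F`, with dimethylcarbamoyl in place of acetamido on an aromatic carbon. Like compound 3, compound 4 lacks the amide hydrogen of compound 2. That makes the closest guide the change of methyl in place of hydrogen on an amide-type nitrogen, which gives an at least 2.5-fold higher number from compound 2 to compound 3 (0.40 log units; beyond the scatter). Acetyl(methyl)amino in place of ethyl gives an at least 3.8-fold higher number from compound 1 to compound 3 (0.58 log units; beyond the scatter). Going by these compounds, both of these steps end at a limit, so their true sizes are unknown. Dimethylcarbamoyl is also a different group from acetyl(methyl)amino, so only part of such a step is expected to carry over.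

The expected step in this assay points to a higher number: a 1.8-fold higher number from compound 2 to compound 4 (0.25 log units; within the scatter). For compound 4 the estimated value is 70 uM, with an expected range from 30 uM to 100 uM.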

Compound 4, half-maximal toxic concentration: 80.1 uM
Compound 4: middle estimate off by 1.1-fold (0.06 log units), on the low side, within the range that was stated.
By their numbers in this assay, from the lowest: compounds 1 and 2 (each within the scatter of the next); then compound 4. At a limit, above all of these: compound 3.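

In this assay, dimethylcarbamoyl in place of acetamido on an aromatic carbon gives a 2.0-fold higher number from compound 2 to compound 4 (0.31 log units; beyond the scatter), so this swap produces a step that can be sized. Measured against the plain ethyl group, the change is larger, with a 3.1-fold higher number from compound 1 to compound 4 (0.49 log units; beyond the scatter), whereas acetamido in place of ethyl stayed within the scatter. Going by these compounds, compound 3 stands at a limit rather than a number: the limit of > 100 uM in this assay, at which 1 of the 4 values shown sits. Dimethylcarbamoyl in place of acetyl(methyl)amino on an aromatic carbon gives an at least 1.2-fold lower number from compound 3 to compound 4 (0.09 log units; that floor lies within the scatter), and the true size of this step is unknown.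

The compounds shown leave open whether the higher number in compound 4 follows from losing the amide hydrogen or from some other feature of the dimethylcarbamoyl group, as this swap changes more than that one hydrogen. On these data alone, they also give no reading for a carboxylic acid, a free amine or a longer chain on the same aromatic carbon, so how far the trend extends beyond these four compounds remains unknown.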